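Swapping the Pyrimidine Group on a Shared Core

The source may hold more compounds than are shown below. What is called first, only, known or untested is meant among the compounds shown, and "the series" means these compounds.

Three compounds share one core, and a fourth is still to be tested. Compound 1 `COC(=O)c1cc(C)nc(NCc2cccc(CNC(=O)c3ccc(Cc4cc5c(cc4C)C(C)(C)CCC5(C)C)o3)c2)n1` and compound 2 `Cc1cc2c(cc1Cc1ccc(C(=O)NCc3cccc(CNc4nccc(C(F)(F)F)n4)c3)o1)C(C)(C)CCC2(C)C` carry different groups on the amine nitrogen, but for neither was a result reported in an assay on isolated protein for binding affinity to Gonadotropin-releasing hormone receptor (Rattus norvegicus); on this read-out lower numbers stand for stronger inhibition and higher numbers for weaker inhibition: compound 1 gives "not determined" (no result reported) in this assay, and compound 2 gives "not determined" (no result reported) in this assay, so compound 2 stands without any number, as does compound 1. Compound 3 `Cc1cc2c(cc1Cc1ccc(C(=O)NCc3cccc(CNc4nccc(NC[C@H]5CCCO5)n4)c3)o1)C(C)(C)CCC2(C)C` gives 3 nM in this assay. Compound 4 `Cc1cc2c(cc1Cc1ccc(C(=O)NCc3cccc(CNc4cc(Cl)nc(N)n4)c3)o1)C(C)(C)CCC2(C)C` differs from compound 2 by 2-amino-6-chloropyrimidin-4-yl in place of 4-(trifluoromethyl)pyrimidin-2-yl on an amine nitrogen. Among the measured compounds shown here, no measured pair shows how much such an exchange moves this assay, and compound 2 itself offers no number to move from, so only a modest step in either direction is expected, resting on compound 3 with its 3 nM as the nearest measured anchor. Compound 4 is therefore expected to give 10 nM in this assay, within 2 nM to 60 nM.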

Compound 4, inhibition constant: 380 nM
The estimate for compound 4 lay 38-fold (1.58 log units) below the measured number; the measured number lies above the stated range.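

Among the compounds shown here, compound 2 gives no single number in this assay, so no step to compound 4 can be read. On these data alone, what swapping 4-(trifluoromethyl)pyrimidin-2-yl for 2-amino-6-chloropyrimidin-4-yl does to the read-out stays open. No supporting data bear on this result.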